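Working notes: removing the 2-cyclopropylethynyl arm from compound 2

The source may report more compounds than this note shows. Statements on the series, on what has been measured and on what is new or still open speak of the compounds shown alone.

Measured so far:
Compound 2 `O=c1nc2oc(C3CC3)c(C#CC3CC3)c2cn1Cc1cn(Cc2ccccc2)nn1`: 6510 nM
Compound 3 `O=c1nc2oc(C3CC3)c(C#CC3CC3)c2cn1Cc1cn(-c2ccccc2F)nn1`: 51200 nM
Compound 1 `CCCCCCc1cc2cn(Cc3cn(Cc4ccccc4)nn3)c(=O)nc2o1`: 59400 nM

In a functional assay on HeLa cells (Homo sapiens) for antiproliferative activity, read by MTT assay, with a stated time of 72 h (a lower number here means a stronger inhibitor, a higher number a weaker inhibitor), compound 2 stands lowest of the three numbers shown. Its nearest neighbour is compound 3, reached by a 7.9-fold higher number from compound 2 to compound 3 (0.90 log units; beyond the scatter); compound 1, which carries hexyl and no alkyne, lies further off and is the highest number of the set.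

Compound 4 `O=c1nc2oc(C3CC3)cc2cn1Cc1cn(Cc2ccccc2)nn1` keeps the core of compound 2 and changes it in one place: hydrogen in place of 2-cyclopropylethynyl on an aromatic carbon. For the measured compounds named here, no measured step concerns this position; the only measured step, a 7.9-fold higher number from compound 2 to compound 3 (0.90 log units; beyond the scatter), changes the group on the aromatic nitrogen and so bears little on it. Compound 1 also lacks the 2-cyclopropylethynyl group but differs in a second place as well, so it gives only a loose hint that the number rises. A modest rise beyond the scatter is therefore expected for compound 4, namely a 4.6-fold higher number from compound 2 to compound 4 (0.66 log units; beyond the scatter). For compound 4 the estimate in this assay is 30000 nM, with a range from 8000 nM to 120000 nM.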

Compound 4, half-maximal inhibitory concentration: 50000 nM
The estimate for compound 4 lay 1.7-fold (0.22 log units) below the measured number; the measured number falls inside the stated range.
By their numbers in this assay, from the lowest: compound 2; then compounds 4, 3 and 1 (each within the scatter of the next).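

In this assay, for the compounds shown here, the loss of 2-cyclopropylethynyl from this aromatic carbon gives a 7.7-fold higher number from compound 2 to compound 4 (0.89 log units; beyond the scatter) as the first direct reading of this position, so the arm matters for the number of compound 2. Cyclopropyl in place of hexyl on an aromatic carbon gives a 1.2-fold lower number from compound 1 to compound 4 (0.07 log units; within the scatter) and so, with no arm present, does not separate these two compounds. No supporting data on why the arm matters are at hand.

Open, from the compounds shown here alone, is whether a shorter alkyne such as propynyl, a phenylethynyl group, a nitrile or an amine on this carbon would match compound 2 in this assay or stay with compound 4.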